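Trimming the isopropyl in a weak fused-ring series

A few compounds are considered here, and "the series" means these few. Any claim that something is new, unique, unknown or untested is made for them only; others in the source may bear on it.

Of the compounds shown here, two of one fused core have been measured. Compound 1 `Cc1nc(C2CC2)cc2nn(-c3ccccc3)cc12` carries a methyl and a cyclopropyl; in a functional assay on K562 cells (Homo sapiens) for inhibition, read by fluorescence, with a stated time of 72 h (a higher number here means a weaker inhibitor of growth, a lower number a stronger inhibitor of growth), compound 1 gives 25900 nM. Compound 2 `CCCCc1cc2nn(-c3ccccc3)cc2c(C(C)C)n1` carries an isopropyl and a butyl; in this assay compound 2 gives 12900 nM. Compound 2 holds the lowest of the two numbers, and its nearest neighbour is compound 1, whose value lies within the scatter of it, so no order between the two can be claimed. Both sit in the weak range.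

Compound 3 `CCCCc1cc2nn(-c3ccccc3)cc2c(C)n1` is compound 2 with one change: methyl in place of isopropyl on an aromatic carbon. Going by the values given here, no measured pair shows this exact change, so its size is not known here. Both measured compounds are weak, and the butyl group of compound 2 is kept in compound 3. The step from compound 2 to compound 3 is expected to stay within the scatter, with some chance of a loss: a 1.6-fold higher number from compound 2 to compound 3 (0.19 log units; within the scatter). In this assay compound 3 is therefore estimated at 20000 nM, expected to fall between 7000 nM and 60000 nM.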

Compound 3, concentration for 50% growth inhibition: 8500 nM
For compound 3 the middle estimate is 2.4-fold (0.37 log units) above the measured one; measured number inside the range.
By their numbers in this assay, from the lowest: compounds 3, 2 and 1 (each within the scatter of the next, the first and the last beyond it).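

Methyl and isopropyl, on the aromatic carbon next to the ring nitrogen, cannot be told apart in this assay (a 1.5-fold lower number from compound 2 to compound 3 (0.18 log units; within the scatter)), so at this position the loss of two carbons leaves the number within the scatter, and compound 2 and compound 3 carry no order. Going by these compounds alone, the only step beyond the scatter among the three compounds lies at the other substituted carbon (a 3.0-fold lower number from compound 1 to compound 3 (0.48 log units; beyond the scatter)), where butyl takes the place of cyclopropyl; this step is modest, and it shows that a change at this site can move the number by more than the scatter, while the change from isopropyl to methyl does not. Nothing measured alongside these values accounts for the size of either step.

Within the data shown here, open is whether the carbon next to the ring nitrogen accepts groups of another kind, such as an amine or a carboxylic acid, since only two alkyl groups can be compared there so far. Also open, as far as these compounds go, is whether a longer chain than butyl, or an ether in that chain, carries the gain over cyclopropyl further, or whether the series stays in the weak range.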